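From Compound 1 to Compound 4: Benzoyl for Carbamoyl

The compounds below may be only part of what the source reports. "The series", "measured", "known", "first", "only" and "open" are said of these compounds alone.

Measured compounds:
compound 1 `COc1cc(-c2nn(-c3cccc(NC(=O)Nc4ccc(Cl)c(Cl)c4)c3)cc2-c2ccncc2)ccc1Cl` – > 50000 nM
compound 2 `O=C(Nc1cccc(-n2cc(-c3ccncc3)c(-c3ccc(Cl)c(O)c3)n2)c1)Nc1ccc(Cl)c(Cl)c1` – > 32500 nM
compound 3 `O=C(Nc1cccc(-n2cc(-c3ccncc3)c(-c3ccc(Cl)c(O)c3)n2)c1)Nc1cc(C(F)(F)F)cc(C(F)(F)F)c1` – 4670 nM

Of the compounds shown here, three have been tested in a functional assay on HT-29 cells (Homo sapiens) for inhibition, read by sulforhodamine B assay, with a stated time of 48 h; on this read-out lower numbers stand for higher toxicity in this test and higher numbers for lower toxicity in this test. Compound 1 gives > 50000 nM, which is a limit of the assay and not a number. Compound 2 also gives only a limit, > 32500 nM. Compound 3 gives a number, 4670 nM. Among the compounds with values here, the one step between measured neighbours, a step that the two limits leave unreadable from compound 1 to compound 2, is hydrogen in place of methyl on an oxygen on an aromatic ring; its size cannot be read, since both ends rest at limits (the limit of > 50000 nM in this assay, at which 1 of the 3 values shown sits, and (the limit of > 32500 nM in this assay, at which 1 of the 3 values shown sits)). Compound 1 therefore stands at a limit, and no number places it against compound 3.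

Compound 4 `COc1cc(-c2nn(-c3cccc(NC(=O)c4ccccc4)c3)cc2-c2ccncc2)ccc1Cl` differs from compound 1 by phenyl in place of (3,4-dichlorophenyl)amino on a carbonyl carbon, read one bond further out as (3,4-dichlorophenyl)carbamoyl to benzoyl, or ((3,4-dichlorophenyl)carbamoyl)amino to benzamido. Within the data shown here, no measured step touches this part of the molecule; the only measured step concerns the oxygen on the other ring and is itself unreadable. What can be expected for compound 4 thus rests on compound 1 alone, which sits at a limit. Compound 4 is expected to remain at a limit as well, so that the expected step that the limit leaves unreadable from compound 1 to compound 4 cannot be told from none. The estimate for compound 4 in this assay is 60000 nM, in a range from 15000 nM to 250000 nM.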

Compound 4, concentration lethal to 50% of the cells: > 100000 nM
Compound 4: no number, only a limit (the forecaster's own chance of this, stated with the estimate: 85%); at least 1.6-fold (0.22 log units) between middle value and limit.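

In this assay compound 4 gives > 100000 nM, which is a limit of the assay and not a number. Compound 1 also rests at a limit, so no step can be read between compound 1 and compound 4. The compounds shown leave open how much phenyl in place of (3,4-dichlorophenyl)amino on the carbonyl carbon changes the read-out.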